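The source may hold more compounds than are shown below. What is called first, only, known or untested is meant among the compounds shown, and "the series" means these compounds.

Among the compounds with values here, compound 2 `c1ccc(-c2cc[nH]n2)c(OCC2=NCCN2)c1` gives 5.01 nM in a functional assay for activation of Alpha-1A adrenergic receptor (Homo sapiens), read by calcium flux (a lower number here means that less compound is needed, a higher number that more compound is needed for the effect), the lowest of the two numbers known here; the nearest is compound 1 `c1cnc(-c2ccccc2OCC2=NCCN2)nc1`, which gives 1260 nM. Compound 3 `c1ccc(-c2ccns2)c(OCC2=NCCN2)c1` differs from compound 2 by 1,2-thiazol-5-yl in place of 1H-pyrazol-3-yl on an aromatic carbon. Within the data shown here, the only step known that bears on it, a 250-fold lower number from compound 1 to compound 2 (2.40 log units; beyond the scatter), shows that swapping the aromatic ring on that carbon can change the outcome greatly. Because of that step, compound 3 is estimated to need more compound than compound 2, by a 6.0-fold higher number from compound 2 to compound 3 (0.78 log units; beyond the scatter). For compound 3 a value of 30 nM is expected, within a range from 5 nM to 300 nM.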

Compound 3, half-maximal effective concentration: 5.01 nM
The estimate for compound 3 lay 6.0-fold (0.78 log units) above the measured number; the measured number falls inside the stated range.
By their numbers in this assay, from the lowest: compounds 2 and 3 (each within the scatter of the next); then compound 1.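

In this assay, the step of no change at the digits printed from compound 2 to compound 3 (within the scatter) shows that this position accepts 1,2-thiazol-5-yl as well as 1H-pyrazol-3-yl, even though only the latter carries a hydrogen-bond donor. The step of a 250-fold lower number from compound 1 to compound 3 (2.40 log units; beyond the scatter) shows that the large change first seen with 1H-pyrazol-3-yl is not unique to that group, as a second five-membered aromatic ring with 2 hetero atoms gives it too.

No evidence explains why these two groups match. Going by these compounds, whether a simple phenyl ring, an amine or a carboxylic acid on this aromatic carbon would also give a low number remains open.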